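Triazolyl esters of a hydroxylated terpenoid acid: antiproliferative notes

The source may report more compounds than this note shows. Statements on the series, on what has been measured and on what is new or still open speak of the compounds shown alone.

Measured so far:
Compound 1 `C/C(=C\CC/C(C)=C/CC[C@@H]1[C@@]2(C)CCC(=O)C(C)(C)[C@H]2CC[C@@]1(C)O)CC/C=C(\C)C(=O)OCc1cn(-c2cccc([N+](=O)[O-])c2)nn1`. In a functional assay on A549 cells (Homo sapiens) for antiproliferative activity, read by MTT assay, with a stated time of 48 h (on this read-out lower numbers stand for stronger inhibition and higher numbers for weaker inhibition), compound 1 gives > 150000 nM, which is a limit of the assay and not a number.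
Compound 2 `C/C(=C\CC/C(C)=C/CC[C@@H]1[C@@]2(C)CCC(=O)C(C)(C)[C@H]2CC[C@@]1(C)O)CC/C=C(\C)C(=O)OCc1cn(-c2ccccc2C)nn1`. In this assay compound 2 gives > 150000 nM, again a limit.
Compound 3 `C/C(=C\CC/C(C)=C/CC[C@@H]1[C@@]2(C)CCC(=O)C(C)(C)[C@H]2CC[C@@]1(C)O)CC/C=C(\C)C(=O)O`. In this assay compound 3 gives > 150000 nM, also a limit.

Compound 1 therefore stands only at a limit in this assay; the two other values shown are limits as well, so no ranking among the three is possible. For the measured compounds named here, the one step between measured compounds that differ in a single place, a step that the two limits leave unreadable from compound 1 to compound 2, cannot be read because both ends sit at the limit. The whole picture is summed up by the limit of > 150000 nM in this assay, at which 3 of the 3 values shown sit.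

Compound 4 `C/C(=C\CC/C(C)=C/CC[C@@H]1[C@@]2(C)CCC(=O)C(C)(C)[C@H]2CC[C@@]1(C)O)CC/C=C(\C)C(=O)OCc1cn(-c2ccc(C(C)(C)C)cc2)nn1` is the next one to be measured. It differs from compound 1 as follows: 4-(tert-butyl)phenyl in place of 3-nitrophenyl on an aromatic nitrogen. Going by the values given here, the only step that bears on this change is the unreadable one from compound 1 to compound 2, so no size or direction can be taken from it.

Given that every value shown rests at the limit, compound 4 is expected to remain there too, an expected step that the limit leaves unreadable from compound 1 to compound 4. The estimate for compound 4 in this assay is 200000 nM, with a range from 80000 nM to 600000 nM.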

Compound 4, half-maximal inhibitory concentration: > 150000 nM
Compound 4: only a limit was reported; the forecaster's own chance of this, stated with the estimate: 85%; the middle value does not contradict the limit.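

In this assay compound 4 gives > 150000 nM, a limit of the assay and not a number. The steps to compound 4 from compound 1 and from compound 2 therefore cannot be read. The compounds shown leave open whether any group on that aromatic nitrogen changes antiproliferative activity at all, and the picture stays as it was: the limit of > 150000 nM in this assay, at which 4 of the 4 values shown sit.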